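Amide nitrogen swap from compound 2 to compound 3

The compounds below may be only part of what the source reports. "The series", "measured", "known", "first", "only" and "open" are said of these compounds alone.

Measured so far:
compound 1, `Cc1ccc(CNC(=O)CN2C(=O)/C(=C/c3ccc(-c4ccc(Cl)cc4)o3)SC2=S)cc1`: 45000 nM
compound 2, `O=C(CN1C(=O)/C(=C/c2ccc(-c3ccc(Cl)cc3)o2)SC1=S)NCc1ccc(Br)cc1`: 75000 nM

In a functional assay on REH cells (Homo sapiens) for cytotoxicity, read by MTT assay, with a stated time of 72 h (on this read-out lower numbers stand for stronger inhibition and higher numbers for weaker inhibition), compound 1 gives 45000 nM and compound 2 gives 75000 nM, the two within the scatter of each other. Among the measured compounds shown here, the single measured step, a 1.7-fold higher number from compound 1 to compound 2 (0.22 log units; within the scatter), alters only a substituent on an aromatic carbon.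

Compound 3, `O=C(CN1C(=O)/C(=C/c2ccc(-c3ccc(Cl)cc3)o2)SC1=S)Nc1nnn[nH]1`, differs from compound 2 by 1H-tetrazol-5-yl in place of 4-bromobenzyl on an amide-type nitrogen. No measured step touches the amide nitrogen, so nothing shown bears directly on this change; the one step at hand stayed within the scatter. The expectation is therefore a step of a 1.1-fold lower number from compound 2 to compound 3 (0.03 log units; within the scatter), not beyond the scatter. Compound 3 is estimated at 70000 nM, expected between 30000 nM and 160000 nM.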

Compound 3, half-maximal inhibitory concentration: 50000 nM
The estimate for compound 3 lay 1.4-fold (0.15 log units) above the measured number; low and high end bracket the measured number.
By their numbers in this assay, from the lowest: compounds 1, 3 and 2 (each within the scatter of the next).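

In this assay, the amide-type nitrogen accepts 1H-tetrazol-5-yl in place of either benzyl group without leaving the scatter: a 1.5-fold lower number from compound 2 to compound 3 (0.18 log units; within the scatter), and a 1.1-fold higher number from compound 1 to compound 3 (0.05 log units; within the scatter). The six-membered carbon ring can therefore give way to a five-membered aromatic ring with 4 hetero atoms with no readable change in this assay. Nothing available accounts for this flat result.

Going by these compounds, whether any group on this nitrogen moves the number beyond the scatter stays open, for instance a longer chain ending in a carboxylic acid or an amine. On these data alone, the effect of changes to the shared core also stays open.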